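This account rests on a few compounds, and the source may have more. Where it says the series, first, only, none or still open, it means among the compounds named here.

Compound 1 `N#Cc1ccc(/C=C/S(=O)(=O)Cc2ccc(Nc3ncnc4ccccc34)cc2)cc1` gives > 100000 nM (a limit of the assay)
Compound 2 `O=S(=O)(/C=C/c1ccc(Cl)c(Cl)c1)Cc1ccc(Nc2ncnc3ccccc23)cc1` gives 22000 nM
Compound 3 `O=S(=O)(/C=C/c1ccc(Cl)cc1Cl)Cc1ccc(Nc2ncnc3ccccc23)cc1` gives 5000 nM

In a functional assay on NCI/ADR-RES cells (Homo sapiens) for inhibition (on this read-out lower numbers stand for stronger inhibition of growth and higher numbers for weaker inhibition of growth), compound 3 has the lower of the two actual numbers (5000 nM), and compound 2 stands higher (22000 nM). Compound 1 gives only a limit (> 100000 nM).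

Compound 4 (`O=S(=O)(/C=C/c1ccc(Cl)cc1Cl)Cc1ccc(Nc2ncnc3ccc(Br)cc23)cc1`) keeps all of compound 3 except for one change on the shared core (bromo in place of hydrogen on an aromatic carbon): bromo in place of hydrogen on an aromatic carbon, part of a fused or bridged system of two rings.

The measured steps (an at least 4.5-fold lower number from compound 1 to compound 2 (0.65 log units; beyond the scatter)), (a 4.4-fold lower number from compound 2 to compound 3 (0.64 log units; beyond the scatter)) and (an at least 20-fold lower number from compound 1 to compound 3 (1.30 log units; beyond the scatter)) run from modest to large. All of them alter the phenyl group on the double-bonded chain, never the core, so they give no direction here. The expected result is no shift beyond the scatter (no change at the digits printed from compound 3 to compound 4 (within the scatter)), though a move either way remains possible. For compound 4 the estimated value is 5000 nM, with an expected range from 1500 nM to 20000 nM.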

Compound 4, concentration for 50% growth inhibition: > 100000 nM
Compound 4: only a limit was reported; the forecaster's own chance of this, stated with the estimate: 10%; middle value at least 20-fold (1.30 log units) from the limit.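

In this assay, adding a single bromo to this aromatic carbon of the shared core sharply weakens growth inhibition, giving an at least 20-fold higher number from compound 3 to compound 4 (1.30 log units; beyond the scatter). Among the compounds shown here, this position, unchanged among the earlier compounds, is therefore not indifferent to substitution, and one added heavy atom is enough to produce this loss. Compound 4 gives only a limit, so the step is a minimum and its true size remains unknown: the limit of > 100000 nM in this assay, at which 2 of the 4 values shown sit.

As far as these compounds go, it remains open whether fluoro, methoxy or an amine on this carbon would weaken growth inhibition as much. From the compounds shown here alone, it also remains open whether bromo has the same effect alongside 3,4-dichlorophenyl on the chain.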